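Swapping the Aryl Ring on the Amine of Compound 1

The source may report more compounds than this note shows. Statements on the series, on what has been measured and on what is new or still open speak of the compounds shown alone.

Measured compounds in a functional assay on HT-29 cells (Homo sapiens) for cytotoxicity, read by sulforhodamine B assay; a higher number here means a weaker inhibitor, a lower number a stronger inhibitor:
compound 1 `C=C1[C@@H](OC(C)=O)C[C@@H]2[C@](C)(COC=O)[C@H](OC(C)=O)CC[C@@]2(C)[C@@H]1C[C@@H](Nc1ccc(Br)cc1)C1=CCOC1=O` gives 13200 nM
compound 2 `C=C1[C@@H](OC(C)=O)C[C@@H]2[C@](C)(CO[Si](C)(C)C(C)(C)C)[C@H](OC(C)=O)CC[C@@]2(C)[C@@H]1C[C@@H](Nc1ccc(OC)cc1)C1=CCOC1=O` gives 5370 nM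
compound 3 `C=C1[C@@H](OC(C)=O)C[C@@H]2[C@](C)(CO[Si](C)(C)C(C)(C)C)[C@H](OC(C)=O)CC[C@@]2(C)[C@@H]1C[C@@H](Nc1ccc(C(=O)O)cc1)C1=CCOC1=O` gives 4630 nM

Compound 1 stands at the highest of the three numbers, the weakest inhibitor among them; compound 2 and compound 3 both sit beyond the scatter below it. Within the data shown here, the only single-point step available, a 1.2-fold lower number from compound 2 to compound 3 (0.06 log units; within the scatter), concerns a change on the aromatic ring attached to the amine nitrogen and lies within the scatter.

Compound 4 `C=C1[C@@H](OC(C)=O)C[C@@H]2[C@](C)(COC=O)[C@H](OC(C)=O)CC[C@@]2(C)[C@@H]1C[C@@H](Nc1cccc2ccccc12)C1=CCOC1=O` is made from compound 1 by one change: naphthalen-1-yl in place of 4-bromophenyl on an amine nitrogen. Among the measured compounds shown here, no measured pair shows this exact exchange, and compound 2 and compound 3 differ from compound 1 elsewhere as well, so the step from compound 2 to compound 3 only hints that altering the aryl ring on the amine moved the number little. On that basis no step beyond the scatter is expected, and the estimated step is a 1.3-fold lower number from compound 1 to compound 4 (0.12 log units; within the scatter). Compound 4 is therefore expected to give about 10000 nM, within a range of 4000 nM to 30000 nM.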

Compound 4, half-maximal inhibitory concentration: 8670 nM
For compound 4 the middle estimate is 1.2-fold (0.06 log units) above the measured one; the range from low to high includes it.
By their numbers in this assay, from the lowest: compounds 3, 2, 4 and 1 (each within the scatter of the next, the first and the last beyond it).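

In this assay, the exchange of 4-bromophenyl for naphthalen-1-yl on the amine nitrogen gives a 1.5-fold lower number from compound 1 to compound 4 (0.18 log units; within the scatter), so this step lies within the scatter. Unlike the earlier comparison of compound 2 and compound 3, this pair tests the aryl group with the rest of compound 1 left unchanged, and it shows that going from one six-membered aromatic ring to two, and from 7 to 10 heavy atoms, does not take the number beyond the scatter. Nothing shown here gives a cause for this result.

Going by these compounds, it remains open whether a cyclohexyl group or a pyridin-3-yl group on the same amine nitrogen would also stay within the scatter of compound 1. On these data alone, it is also open whether naphthalen-1-yl would read the same way on the silyl ether carried by compound 2 and compound 3.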